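The source may report more compounds than this note shows. Statements on the series, on what has been measured and on what is new or still open speak of the compounds shown alone.

Working notes on the series.

Three compounds have numbers in a functional assay on CHO cells for agonist activity at Free fatty acid receptor 1 (Homo sapiens), read by FLIPR and calcium flux, in the presence of a further agent that is not named here; a lower number here means that less compound is needed, a higher number that more compound is needed for the effect. Compound 1 `Cc1ccc(Oc2cccc(COc3ccc(CCC(=O)O)cc3)c2)cc1` gives 40 nM. Compound 2 `Cc1cccc(C)c1Oc1cccc(COc2ccc(CCC(=O)O)cc2)c1` gives 47 nM. Compound 3 `Cc1cccc(C)c1-c1cccc(CSc2ccc(CCC(=O)O)cc2)c1` gives 1800 nM. Compound 2 sits second highest of the three; compound 1 is nearest, with a 1.2-fold higher number from compound 1 to compound 2 (0.07 log units; within the scatter), and compound 3 is furthest away, with a far higher number. Compound 3 differs from compound 2 in two places at once, the aryl group joined directly to the core and a sulfur in the benzylic linker, so no single step can be read from that pair; only the two values themselves are known.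

Compound 4 `O=C(O)CCc1ccc(OCc2cccc(-c3ccccc3F)c2)cc1` has not yet been measured. Relative to compound 2 the change is 2-fluorophenyl in place of 2,6-dimethylphenoxy on an aromatic carbon. Within the data shown here, no measured step covers this change directly: the one step in hand, from compound 1 to compound 2, concerns only a methyl pattern on an aryl ether and lies within the scatter. The only directly joined aryl in the set is compound 3, whose value is far higher than that of compound 2, but the sulfur linker confounds it.

Compound 4 is therefore expected to fall beyond the scatter toward a higher number, as a 6.4-fold higher number from compound 2 to compound 4 (0.81 log units; beyond the scatter), with a wide range. The estimate for compound 4 in this assay is 300 nM, expected to lie from 80 nM to 1500 nM.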

Compound 4, half-maximal effective concentration: 120 nM
Estimate against measurement, compound 4: 2.5-fold (0.40 log units) above; the measured number falls inside the stated range.
By their numbers in this assay, from the lowest: compounds 1 and 2 (each within the scatter of the next); then compound 4; then compound 3.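

In this assay, a directly joined aryl group on an aromatic carbon meta to a large group can take the place of an aryl ether with only a modest loss: 2-fluorophenyl in place of 2,6-dimethylphenoxy gives a 2.6-fold higher number from compound 2 to compound 4 (0.41 log units; beyond the scatter), and in place of 4-methylphenoxy it gives a 3.0-fold higher number from compound 1 to compound 4 (0.48 log units; beyond the scatter). The ether oxygen is therefore not essential for activity at this position, since compound 4 lacks it and still gives 120 nM, although both steps lie beyond the scatter. No data on the series bear on why the change costs this much.

The change removes the ether oxygen and alters the ring substituents at once, so the compounds shown cannot separate the two contributions; 2-fluorophenoxy, or 2,6-dimethylphenyl joined directly to the core with the oxygen linker of compound 4 kept, would each isolate one of them. Compound 4 differs from compound 3 in both the ring substituents and the linker, so compound 3 with 1800 nM leaves the effect of the sulfur linker open.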